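Methyl to nitro exchange in a two-compound amide series

A few compounds are considered here, and "the series" means these few. Any claim that something is new, unique, unknown or untested is made for them only; others in the source may bear on it.

Measured so far:
compound 1 `O=C(/C=C/c1ccccc1)c1cccc(NC(=O)c2cc(-c3ccncc3)n[nH]2)c1`, 67100 nM
compound 2 `Cc1ccc(/C=C/C(=O)c2cccc(NC(=O)c3cc(-c4ccncc4)n[nH]3)c2)cc1`, 69400 nM

Within the data shown here, in a functional assay, read by spectrophotometry, tested at 100 uM (a higher number here means a weaker inhibitor, a lower number a stronger inhibitor), compound 2 stands at 69400 nM and compound 1 at 67100 nM; the single step of a 1.0-fold higher number from compound 1 to compound 2 (0.01 log units; within the scatter) is within the scatter, so the two are not distinguished. Compound 3 `O=C(/C=C/c1ccc([N+](=O)[O-])cc1)c1cccc(NC(=O)c2cc(-c3ccncc3)n[nH]2)c1` differs from compound 2 by nitro in place of methyl on an aromatic carbon. Among the measured compounds shown here, the only step that bears on this position is the one from hydrogen to methyl, and it moved nothing beyond the scatter; no measured step covers a nitro group. The expectation is therefore a 1.2-fold lower number from compound 2 to compound 3 (0.06 log units; within the scatter), no shift beyond the scatter. Compound 3 is estimated at 60000 nM, in a range of 25000 nM to 150000 nM.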

Compound 3, half-maximal inhibitory concentration: 52800 nM
For compound 3 the middle estimate is 1.1-fold (0.06 log units) above the measured one, within the range that was stated.
By their numbers in this assay, from the lowest: compounds 3, 1 and 2 (each within the scatter of the next).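

In this assay nitro in place of methyl gives a 1.3-fold lower number from compound 2 to compound 3 (0.12 log units; within the scatter) and nitro in place of hydrogen gives a 1.3-fold lower number from compound 1 to compound 3 (0.10 log units; within the scatter), and both steps lie within the scatter. On this aromatic carbon, para to a large group, 4-nitrophenyl is therefore not distinguished from 4-methylphenyl or from the unsubstituted ring, even with more heavy atoms and two hydrogen-bond acceptors entering. No supporting measurement accompanies these numbers to explain this. Open, going by these compounds, is whether an amine or a carboxylic acid on this carbon would give a step beyond the scatter. Also open, on these data alone, is whether any change to the shared core would do so.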